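A few compounds are considered here, and "the series" means these few. Any claim that something is new, unique, unknown or untested is made for them only; others in the source may bear on it.

The two measured compounds are compound 1, `Oc1cccc(-c2cc(-c3cccc(O)c3)nc(-c3ccccc3O)c2)c1`, and compound 2, `Oc1ccc(-c2cc(-c3ccccc3O)cc(-c3ccccc3O)n2)cc1`. In an assay on isolated protein for inhibition of DNA topoisomerase 1 (Homo sapiens), with a stated time of 30 min, tested at 100 uM (a lower number here means less inhibition, a higher number more inhibition at the concentration tested (going by the name of the read-out)), compound 1 gives 1.9%, and in the same assay compound 2 gives 0.3%. Compound 2 holds the lower of the two numbers, yet its gap to compound 1 lies within the scatter of repeated measurements, so the two cannot be told apart on these data. Going by the values given here, no step between measured compounds differing in a single place is available. Compound 3, `Oc1ccc(-c2cc(-c3cccc(O)c3)cc(-c3ccccc3O)n2)cc1`, has the same atoms as compound 2 joined differently: 3-hydroxyphenyl in place of 2-hydroxyphenyl on an aromatic carbon. Since compound 2 gives 0.3% and compound 1 gives 1.9% in this assay, both near zero, the step from compound 2 to compound 3 is expected to be a number 1.7 percentage points higher from compound 2 to compound 3 (within the scatter), nothing beyond the scatter. Compound 3 is therefore estimated at 2% in this assay, within a range from 0% to 12%.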

Compound 3, a percentage reported as inhibition, at one concentration (the size of the read-out at that concentration, not a potency): 8.4%
Estimate against measurement, compound 3: 6.4 percentage points below; measured number inside the range.
By their numbers in this assay, from the lowest: compounds 2, 1 and 3 (each within the scatter of the next).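

In this assay, going by these compounds alone, 3-hydroxyphenyl in place of 2-hydroxyphenyl on the aromatic carbon opposite the ring nitrogen gives a number 8.1 percentage points higher from compound 2 to compound 3 (within the scatter), the first reading at this position, and it shows that this swap of hydroxyphenyl groups cannot be separated from the scatter. The second single change, 4-hydroxyphenyl in place of 3-hydroxyphenyl on an aromatic carbon, gives a number 6.5 percentage points higher from compound 1 to compound 3 (within the scatter), so neither of the two steps now available rises beyond the scatter. Nothing at hand bears on why these numbers stand as they do.

The compounds shown leave open whether a group other than a hydroxyphenyl at this carbon, such as an aminophenyl or a carboxylic acid, would give a step beyond the scatter. They also leave open whether removing the hydroxyl and leaving a plain phenyl there would change the reading.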